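The compounds below may be only part of what the source reports. "The series", "measured", "known", "first", "only" and "open" are said of these compounds alone.

Of the compounds shown here, three that share one core have been tested for how strongly they harm a human cell line. Compound 1, `Cc1cc(-c2ccc(F)cc2)cc(C)c1Oc1cc(N)nc(Nc2ccc(C#N)cc2)n1`, gives 23100 nM in a toxicity assay on MT4 cells (Homo sapiens) for cytotoxicity, read by MTT assay; on this read-out lower numbers stand for higher toxicity in this test and higher numbers for lower toxicity in this test. Compound 2, `Cc1cc(-c2ccccc2C#N)cc(C)c1Oc1cc(N)nc(Nc2ccc(C#N)cc2)n1`, gives 25400 nM in this assay. Compound 3, `Cc1cc(-c2ccc(F)cc2)ccc1Oc1cc(N)nc(Nc2ccc(C#N)cc2)n1`, gives 20100 nM in this assay. All three numbers lie close together.

Compound 2 is made from compound 1 by one change, (2-cyanophenyl in place of 4-fluorophenyl on an aromatic carbon), and this gives a 1.1-fold higher number from compound 1 to compound 2 (0.04 log units; within the scatter). Compound 3 is made from compound 1 by a different change, (hydrogen in place of methyl on an aromatic carbon), and this gives a 1.1-fold lower number from compound 1 to compound 3 (0.06 log units; within the scatter). So neither change moved the number beyond what repeated measurements of this kind normally show.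

Compound 4, `Cc1cc(-c2ccccc2C#N)ccc1Oc1cc(N)nc(Nc2ccc(C#N)cc2)n1`, has not yet been measured. It differs from compound 3 by 2-cyanophenyl in place of 4-fluorophenyl on an aromatic carbon. Going by the values given here, this is the same kind of change as the one from compound 1 to compound 2, though the place is not identical: in compound 1 the changing group is meta to two methyl groups, in compound 3 it is meta to a methyl group.

Because the same kind of change gave a 1.1-fold higher number from compound 1 to compound 2 (0.04 log units; within the scatter), the expected step from compound 3 to compound 4 in this assay is a 1.1-fold higher number from compound 3 to compound 4 (0.04 log units; within the scatter). On that basis compound 4 is expected to give about 22000 nM in this assay. Given the usual scatter, the estimate for compound 4 is expected to fall between 12000 nM and 40000 nM.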

Compound 4, half-maximal cytotoxic concentration: 28600 nM
Compound 4: middle estimate off by 1.3-fold (0.11 log units), on the low side, and the stated range covers the measured number.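

In this assay, 2-cyanophenyl in place of 4-fluorophenyl gives a 1.4-fold higher number from compound 3 to compound 4 (0.15 log units; within the scatter), and this step agrees with the same change made on the core of compound 1: the same change on two cores in this assay, a 1.1-fold higher number (0.04 log units; within the scatter) from compound 1 to compound 2 and a 1.4-fold higher number (0.15 log units; within the scatter) from compound 3 to compound 4, 1.3-fold (0.11 log units) apart, within the scatter of two such steps. Hydrogen in place of methyl gives a 1.1-fold higher number from compound 2 to compound 4 (0.05 log units; within the scatter), and this step likewise agrees with its earlier counterpart: the same change on two cores in this assay, a 1.1-fold lower number (0.06 log units; within the scatter) from compound 1 to compound 3 and a 1.1-fold higher number (0.05 log units; within the scatter) from compound 2 to compound 4, 1.3-fold (0.11 log units) apart, within the scatter of two such steps. Within these four compounds, each change therefore behaves alike on both cores, but as every step lies within the scatter, this shows only that neither change produced a clear shift in the number on either core, not that a larger, real effect would carry over from one core to another in the same way.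

Going by these compounds alone, the four compounds cover only two aromatic groups and the presence or absence of one methyl group, so they cannot show whether a step beyond the scatter is possible anywhere. As far as these compounds go, it remains open what an amine or a carboxylic acid in place of the 4-fluorophenyl group, or a longer chain such as propyl in place of the methyl group, would do to the number in this assay, and whether such a step would carry between the two cores.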